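Ring exchange from compound 2 to compound 3

This account rests on a few compounds, and the source may have more. Where it says the series, first, only, none or still open, it means among the compounds named here.

Values in a physicochemical assay for lipophilicity, using the shake flask method, measured as octanol-water partition, at pH 7.4; a lower number here means a more polar compound, a higher number a more lipophilic compound:
- compound 1 `CC(=O)N[C@@H]1CCC[C@H](C(=O)Nc2cc(-c3cnc4n3CCCC4)c(Cl)cn2)C1`: 2.7
- compound 2 `CC(=O)N[C@@H]1CCC[C@H](C(=O)Nc2cc(-c3cnn4c3CCCCC4)c(Cl)cn2)C1`: 3.6

Compound 2 holds the higher of the two numbers, at 3.6, and compound 1 lies beyond the scatter under it. The next compound is compound 3 `CC(=O)N[C@@H]1CCC[C@H](C(=O)Nc2cc(-c3cnn4c3CN(C)CC4)c(Cl)cn2)C1`. The change is a group of 10 heavy atoms (7 carbon, 3 nitrogen; one five-membered aromatic ring with 2 hetero atoms, one six-membered non-aromatic ring with 2 hetero atoms) in place of a group of 10 heavy atoms (8 carbon, 2 nitrogen; one five-membered aromatic ring with 2 hetero atoms, one seven-membered non-aromatic ring with 1 hetero atom), on an aromatic carbon.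

Within the data shown here, only one measured step bears on this: a number 0.90 log units higher from compound 1 to compound 2 (beyond the scatter). That step brought in the seven-membered non-aromatic ring with 1 hetero atom, which compound 3 gives up for a six-membered non-aromatic ring with 2 hetero atoms. Among the measured compounds shown here, compound 1, at 2.7, is the only measured compound with a six-membered non-aromatic ring, so a fall of about that size is the starting expectation. For the measured compounds named here, no measured step covers the extra ring nitrogen, which leaves the size uncertain. The expected step in this assay is a number 1.10 log units lower from compound 2 to compound 3 (beyond the scatter), somewhat larger than the single measured one. For compound 3 the estimate is 2.5, with an expected range of 2 to 3.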

Compound 3, distribution coefficient: 2.1
Compound 3: the middle estimate sits 0.40 log units above what was measured, within the range that was stated.
By their numbers in this assay, from the lowest: compound 3; then compound 1; then compound 2.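

In this assay, the exchange at this position, on an aromatic carbon ortho to the chloro group, spans more than the ring change seen so far: the step is a number 1.50 log units lower from compound 2 to compound 3 (beyond the scatter), against the earlier a number 0.90 log units higher from compound 1 to compound 2 (beyond the scatter), and it runs in the opposite direction. The step of a number 0.60 log units lower from compound 1 to compound 3 (beyond the scatter) shows that the size of the non-aromatic ring does not alone set the number, since compound 1 and compound 3 both carry a six-membered non-aromatic ring and still lie apart beyond the scatter. Compound 3 also takes the lowest place of the three, so this position allows the number to move in both directions across the measured set, with no measurement on hand to give a reason for the fall.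

The compounds shown do not separate the extra ring nitrogen from its methyl group, from the smaller ring, or from the different arrangement of hetero atoms in the five-membered aromatic ring. Also open, on these data alone, is how the number would respond to an acetyl group in place of that methyl, or to a ring oxygen in place of the methyl-bearing nitrogen.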